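A few compounds are considered here, and "the series" means these few. Any claim that something is new, unique, unknown or untested is made for them only; others in the source may bear on it.

Measured so far:
compound 1 `O=C1NCCN(c2cccc(Br)n2)N1`: 3500 nM
compound 2 `O=C1NCCN(c2cccc(-c3cccs3)n2)N1`: 8200 nM

In an assay on RBL-1 cells for inhibition of Polyunsaturated fatty acid 5-lipoxygenase (Rattus norvegicus) (on this read-out higher numbers stand for weaker inhibition and lower numbers for stronger inhibition), compound 2 holds the higher of the two numbers, the weaker inhibition. Among the measured compounds shown here, the only measured step is a 2.3-fold higher number from compound 1 to compound 2 (0.37 log units; beyond the scatter), modest but beyond the scatter.

Compound 3 `O=C1NCCN(c2cccc(-c3ccccn3)n2)N1` differs from compound 2 by pyridin-2-yl in place of thiophen-2-yl on an aromatic carbon. For the measured compounds named here, no measured step exchanges one aromatic ring for another; the single step known, bromo to thiophen-2-yl, bears on this change only loosely, so no direction is indicated. The expected step is therefore a 1.0-fold lower number from compound 2 to compound 3 (0.01 log units; within the scatter), within the scatter. The estimate for compound 3 is 8000 nM, with a range from 3000 nM to 25000 nM.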

Compound 3, half-maximal inhibitory concentration: 6000 nM
The estimate for compound 3 lay 1.3-fold (0.12 log units) above the measured number, and the stated range covers the measured number.
By their numbers in this assay, from the lowest: compounds 1, 3 and 2 (each within the scatter of the next, the first and the last beyond it).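

In this assay, pyridin-2-yl in place of thiophen-2-yl on this carbon next to the ring nitrogen gives a 1.4-fold lower number from compound 2 to compound 3 (0.14 log units; within the scatter) and so leaves the two rings unseparated. Pyridin-2-yl in place of bromo gives a 1.7-fold higher number from compound 1 to compound 3 (0.23 log units; within the scatter) and so does not separate compound 3 from compound 1 either, unlike the thiophen-2-yl of compound 2. No available evidence bears on the reason for these numbers.

As far as these compounds go, whether any group here can move the number well away from these values stays open. An amine, a carboxylic acid or a longer alkyl chain at this carbon would test that.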